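A biphenyl amide replaces difluorophenyl on a flavonol amide

The compounds below may be only part of what the source reports. "The series", "measured", "known", "first", "only" and "open" are said of these compounds alone.

Compound 3 `O=C(Nc1cccc(-c2oc3cc(-c4ccc(F)cc4)ccc3c(=O)c2O)c1)c1cc(F)cc(F)c1` holds the lowest number among the three measured compounds in a functional assay on MDA-MB-231 cells (Homo sapiens) for antiproliferative activity, read by CCK-8 assay, with a stated time of 72 h (a higher number here means a weaker inhibitor, a lower number a stronger inhibitor), where compound 3 gives 2440 nM. Compound 1 `COc1ccccc1C(=O)Nc1cccc(-c2oc3cc(-c4ccc(F)cc4)ccc3c(=O)c2O)c1` gives 5110 nM in this assay, and compound 2 `COc1ccc(C(=O)Nc2cccc(-c3oc4cc(-c5ccc(F)cc5)ccc4c(=O)c3O)c2)c(F)c1` gives 17600 nM. These three differ only in the aryl group attached to the amide carbonyl: the step of a 2.1-fold lower number from compound 1 to compound 3 (0.32 log units; beyond the scatter) and the step of a 7.2-fold lower number from compound 2 to compound 3 (0.86 log units; beyond the scatter) both end at compound 3, while the step of a 3.4-fold higher number from compound 1 to compound 2 (0.54 log units; beyond the scatter) runs the other way.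

Compound 4 `O=C(Nc1cccc(-c2oc3cc(-c4ccc(F)cc4)ccc3c(=O)c2O)c1)c1ccc(-c2ccccc2)cc1` has not yet been measured. Its change from compound 3 is 4-phenylphenyl in place of 3,5-difluorophenyl on a carbonyl carbon. All three measured steps bear on this change, since each one exchanges the aryl group on the same carbonyl carbon, and together they span a modest range in both directions. Among the compounds with values here, none of them introduces a second ring, so there is no direct precedent for 4-phenylphenyl among the measured compounds. The step of a 1.4-fold higher number from compound 3 to compound 4 (0.16 log units; within the scatter) is therefore expected to be small, with its direction uncertain and a wide range allowed. Compound 4 is estimated to give 3500 nM in this assay, within a range from 900 nM to 14000 nM.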

Compound 4, half-maximal inhibitory concentration: 63200 nM
Compound 4: the middle estimate sits 18-fold (1.26 log units) below what was measured, outside the stated range (above it).
By their numbers in this assay, from the lowest: compound 3; then compound 1; then compound 2; then compound 4.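

The change to 4-phenylphenyl on this carbonyl carbon, which brings a second six-membered aromatic ring of carbon only, gives in this assay a 26-fold higher number from compound 3 to compound 4 (1.41 log units; beyond the scatter) and so exceeds every step seen among the earlier aryl groups. The rise is not tied to the 3,5-difluorophenyl starting point: the same exchange gives a 12-fold higher number from compound 1 to compound 4 (1.09 log units; beyond the scatter) from 2-methoxyphenyl and a 3.6-fold higher number from compound 2 to compound 4 (0.56 log units; beyond the scatter) from 2-fluoro-4-methoxyphenyl. The earlier compounds shown here showed this position accepting exchanges among aryl groups with one ring at a moderate cost, whereas this two-ring group leaves compound 4 with the highest number of the four compounds, and none of the other three goes against that. No measurement shown here accounts for the rise.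

The compounds shown leave open whether the second ring itself or the added length carries the loss, since a single phenyl ring bearing a longer chain such as n-butyl would separate the two. On these data alone, it also remains open whether an amine or a carboxylic acid on the second phenyl ring of 4-phenylphenyl would bring the number back down.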